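The source may hold more compounds than are shown below. What is called first, only, known or untested is meant among the compounds shown, and "the series" means these compounds.

Measured so far in a functional assay on HT cells (Homo sapiens) for antiproliferative activity, read by fluorescence, with a stated time of 72 h; on this read-out higher numbers stand for weaker inhibition of growth and lower numbers for stronger inhibition of growth:
- compound 1 `CC(C)c1n[nH]c2c(NCc3ccc(-c4ccccn4)cc3)nc(SCC(O)CN)nc12` gives 55 nM 
- compound 2 `CC(C)c1n[nH]c2c(NCc3ccc(-c4ccccn4)cc3)nc(SCCCO)nc12` gives 109 nM 

These two compounds share the same core and differ only in the chain on the sulfur. Compound 2, at 109 nM, lies within the scatter of compound 1, so the pair shows no real order. Compound 3 `CC(C)c1n[nH]c2c(NCc3ccc(-c4ccccn4)cc3)nc(SC3CCCCC3O)nc12` is the next to consider, and the change from compound 2 reads 2-hydroxycyclohexyl in place of 3-hydroxypropyl on a sulfur in that place. The hydroxyl-bearing chain thus gives way to 2-hydroxycyclohexyl on a sulfur.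

For the measured compounds named here, only one measured step bears on this, and it does so loosely. That step, a 2.0-fold higher number from compound 1 to compound 2 (0.30 log units; within the scatter), also alters the group on the sulfur, and it stays within the scatter. Going by the values given here, no measured compound carries a ring there, so the data cannot say what the ring will do. The expectation is therefore for no step beyond the scatter, with wide margins on either side. The expected step is a 1.2-fold lower number from compound 2 to compound 3 (0.08 log units; within the scatter) in this estimate. Compound 3 is estimated at 90 nM, with an expected range from 30 nM to 270 nM in this assay.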

Compound 3, concentration for 50% growth inhibition: 636 nM
For compound 3 the middle estimate is 7.1-fold (0.85 log units) below the measured one, outside the stated range (above it).
By their numbers in this assay, from the lowest: compounds 1 and 2 (each within the scatter of the next); then compound 3.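

The sulfur position, where the two open chains had shown no step beyond the scatter, now proves sensitive to the group it carries: in this assay the 2-hydroxycyclohexyl group gives a 5.8-fold higher number from compound 2 to compound 3 (0.77 log units; beyond the scatter), and set against the 3-amino-2-hydroxypropyl chain it gives a 12-fold higher number from compound 1 to compound 3 (1.06 log units; beyond the scatter). The 3-hydroxypropyl and 2-hydroxycyclohexyl groups each hold a hydroxyl and count the same hydrogen-bond donors and acceptors, so among these compounds a hydroxyl on the sulfur substituent does not by itself keep the number low. Nothing measured here accounts for the rise seen with the six-membered ring.

On these data alone, it stays open whether the higher number follows the ring as such or the placing of its hydroxyl, a question that a plain cyclohexyl, a cyclopentyl ring or a 2-aminocyclohexyl group on the sulfur could help to settle. As far as these compounds go, it is also open how far the open chains extend the pattern, for instance a longer hydroxyalkyl chain or a chain ending in a carboxylic acid.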